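Ester variation on a diterpenoid lactone series

The source may hold more compounds than are shown below. What is called first, only, known or untested is meant among the compounds shown, and "the series" means these compounds.

Measured so far:
compound 1 `C=C1C(=O)[C@@]23C(=O)OC[C@]4([C@@H](OC(C)=O)CCC(C)(C)[C@H]4C=O)[C@@H]2CC[C@@H]1[C@H]3O` — 75400 nM
compound 2 `C=C1C(=O)[C@@]23C(=O)OC[C@]4(C(=O)CCC(C)(C)[C@H]4C=O)[C@@H]2CC[C@@H]1[C@H]3OC(C)=O` — 1730 nM
compound 3 `C=C1C(=O)[C@@]23C(=O)OC[C@]4(C(=O)CCC(C)(C)[C@H]4C=O)[C@@H]2CC[C@@H]1[C@H]3OC(=O)c1ccc(OC)cc1` — 2800 nM

Compound 1 `C=C1C(=O)[C@@]23C(=O)OC[C@]4([C@@H](OC(C)=O)CCC(C)(C)[C@H]4C=O)[C@@H]2CC[C@@H]1[C@H]3O` was tested in a functional assay on Bel-7402 cells (Homo sapiens) for cytotoxicity, read by MTT assay, with a stated time of 72 h (a lower number here means a stronger inhibitor, a higher number a weaker inhibitor), and gives 75400 nM. Among the measured compounds shown here, compound 2 `C=C1C(=O)[C@@]23C(=O)OC[C@]4(C(=O)CCC(C)(C)[C@H]4C=O)[C@@H]2CC[C@@H]1[C@H]3OC(C)=O` gives 1730 nM in this assay; no single-point step links it to compound 1, so the two values are only set side by side here. Compound 3 `C=C1C(=O)[C@@]23C(=O)OC[C@]4(C(=O)CCC(C)(C)[C@H]4C=O)[C@@H]2CC[C@@H]1[C@H]3OC(=O)c1ccc(OC)cc1` gives 2800 nM in this assay. Among the three numbers compound 3 stands second highest: nearest to it is compound 2, and the one step that has been resolved, a 1.6-fold higher number from compound 2 to compound 3 (0.21 log units; within the scatter), lies within the scatter. Compound 1 is furthest, with the higher number.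

The next compound, compound 4 `C=C1C(=O)[C@@]23C(=O)OC[C@]4(C(=O)CCC(C)(C)[C@H]4C=O)[C@@H]2CC[C@@H]1[C@H]3OC(=O)c1ccccc1Cl`, differs from compound 3 only at the ester: 2-chlorophenyl in place of 4-methoxyphenyl on a carbonyl carbon. For the measured compounds named here, the only measured step touching this ester is the exchange of methyl for 4-methoxyphenyl, a 1.6-fold higher number from compound 2 to compound 3 (0.21 log units; within the scatter), which did not move the number beyond the scatter. Swapping one aryl ring for another on the same carbonyl carbon is therefore expected to give no step beyond the scatter in this assay, in either direction; the estimated step is a 1.1-fold higher number from compound 3 to compound 4 (0.03 log units; within the scatter). For compound 4 the estimate in this assay is 3000 nM, with a range from 1200 nM to 7500 nM.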

Compound 4, half-maximal inhibitory concentration: 2890 nM
Estimate against measurement, compound 4: 1.0-fold (0.02 log units) above; low and high end bracket the measured number.
By their numbers in this assay, from the lowest: compounds 2, 3 and 4 (each within the scatter of the next); then compound 1.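

In this assay the exchange of one aryl ring for another on this carbonyl carbon gives a 1.0-fold higher number from compound 3 to compound 4 (0.01 log units; within the scatter) and the exchange of methyl for 2-chlorophenyl gives a 1.7-fold higher number from compound 2 to compound 4 (0.22 log units; within the scatter), so a second aryl ester, this one carrying chlorine on the ring in place of a methoxy group, also stays within the scatter. Among the compounds shown here, compound 2, compound 3 and compound 4 thus place methyl, 4-methoxyphenyl and 2-chlorophenyl on the same carbonyl carbon with all three pairs printed within the scatter, and the number so far does not separate these three groups. No measured evidence accompanies these values to account for this flat result.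

The groups shown at this ester are limited to methyl and two substituted phenyl rings, so it remains open whether an amine, a carboxylic acid or a longer alkyl chain on this carbonyl carbon would move the number beyond the scatter. Compound 1 at 75400 nM differs from the other compounds in more than one place, so its value remains unassigned to any single change.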